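Two benzamides against metabotropic glutamate receptor 5

This account rests on a few compounds, and the source may have more. Where it says the series, first, only, none or still open, it means among the compounds named here.

The compounds share one core, an amide-linked bicyclic system carrying a pyridine ring. Compound 1, `O=C(c1ccccc1)N1CCn2nc(-c3ccncc3)cc2C1`, carries an unsubstituted phenyl on the carbonyl carbon; in a functional assay on HEK293 cells for negative allosteric modulation of metabotropic glutamate receptor 5 (Homo sapiens), read by calcium flux, with a stated time of 20 min (on this read-out higher numbers stand for weaker inhibition and lower numbers for stronger inhibition), compound 1 gives 1290 nM. Compound 2, `O=C(c1ccccc1Cl)N1CCn2nc(-c3ccccn3)cc2C1`, instead carries a 2-chlorophenyl on the carbonyl carbon and, in this assay, compound 2 gives 2480 nM. Among the measured compounds shown here, of the two numbers known, compound 2 holds the higher one, but its gap to compound 1 falls within the usual scatter of repeated measurements, so no order between them can be claimed.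

Compound 3, `O=C(c1cc(Cl)cc(Cl)c1)N1CCn2nc(-c3ccccn3)cc2C1`, is not yet measured. It differs from compound 2 in one place: 3,5-dichlorophenyl in place of 2-chlorophenyl on a carbonyl carbon. For the measured compounds named here, no measured pair in this set shows what such a change does, so there is no step to lean on. The expectation is therefore a step of a 1.4-fold lower number from compound 2 to compound 3 (0.14 log units; within the scatter), which is to say none beyond the scatter, in either direction. Compound 3 is estimated to give about 1800 nM in this assay, with a likely range from 450 nM to 7000 nM.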

Compound 3, half-maximal inhibitory concentration: 270 nM
For compound 3 the middle estimate is 6.7-fold (0.82 log units) above the measured one, and the stated range ends above it.
By their numbers in this assay, from the lowest: compound 3; then compounds 1 and 2 (each within the scatter of the next).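

At the carbonyl carbon, the aryl group clearly matters. In this assay, where a lower number means stronger inhibition, 3,5-dichlorophenyl in place of 2-chlorophenyl gives a 9.2-fold lower number from compound 2 to compound 3 (0.96 log units; beyond the scatter), while the rest of the structure stays the same. Among the compounds shown here, this is the first change in the set that can be read on its own, since the two earlier compounds differ in more than one place, and it shows that a change confined to this aryl group can move the number beyond the scatter. Even so, the two groups differ both in how many chlorines they carry and in where those chlorines sit, and nothing measured here explains the step.

Still open, as far as these compounds go, is how much of the step comes from the added chlorine and how much from the new arrangement, and whether methyl, methoxy or nitrile groups could take the place of the chlorines. Also open, from the compounds shown here alone, is whether the same change would have a similar effect on the core of compound 1, whose pyridine ring is attached differently.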